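This account rests on a few compounds, and the source may have more. Where it says the series, first, only, none or still open, it means among the compounds named here.

Measured so far:
compound 1, `N=C(N)c1ccc2cc(-c3cccc(OCCCCOc4ccccc4)c3)oc2c1`, with 7600 nM in an ADME assay on L6 cells (Rattus norvegicus) for cytotoxicity, read by resazurin assay, with a stated time of 70 h; on this read-out lower numbers stand for stronger inhibition and higher numbers for weaker inhibition;
compound 2, `CC(C)NC(=N)c1ccc2cc(-c3cccc(OCCCCOc4ccccc4)c3)oc2c1`, with 46500 nM in this assay;
compound 3, `N=C(N)c1ccc2oc(-c3ccc(OCCCCCOc4ccccc4)cc3)cc2c1`, with 4200 nM in this assay.

Compound 1 and compound 2 share a core and differ in one place: isopropyl in place of hydrogen on an amine nitrogen. That change made a 6.1-fold higher number from compound 1 to compound 2 (0.79 log units; beyond the scatter), a step beyond the usual scatter, so compound 2 is the weaker of the two in this assay. Compound 3 carries a different core; how its core differs from that of compound 1 is not broken down here. Its value and that of compound 1 lie within the scatter of each other, so no order between them can be read.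

Compound 4, `CC(C)NC(=N)c1ccc2oc(-c3ccc(OCCCCCOc4ccccc4)cc3)cc2c1`, has not yet been measured. It differs from compound 3 exactly as compound 2 differs from compound 1: isopropyl in place of hydrogen on an amine nitrogen, at a place whose surroundings read the same in both pairs. It is therefore the same kind of change on a different core. Because the first occurrence gave a 6.1-fold higher number from compound 1 to compound 2 (0.79 log units; beyond the scatter), a step of similar size is expected here, namely a 6.0-fold higher number from compound 3 to compound 4 (0.77 log units; beyond the scatter). Compound 4 is accordingly estimated at 25000 nM, with a likely range from 11000 nM to 55000 nM.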

Compound 4, half-maximal inhibitory concentration: 20500 nM
Estimate against measurement, compound 4: 1.2-fold (0.09 log units) above; the measured number falls inside the stated range.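

Putting isopropyl in place of hydrogen on the amine nitrogen again moved the result in this assay the same way, giving a 4.9-fold higher number from compound 3 to compound 4 (0.69 log units; beyond the scatter) and leaving compound 4 the weaker of this pair. Set beside the first occurrence of this change, the new step agrees with it in size: the same change on two cores in this assay, a 6.1-fold higher number (0.79 log units; beyond the scatter) from compound 1 to compound 2 and a 4.9-fold higher number (0.69 log units; beyond the scatter) from compound 3 to compound 4, 1.3-fold (0.10 log units) apart, within the scatter of two such steps. In these two pairs, then, the change carried from one core to the other with much the same effect on the number, but two pairs do not make a rule for the whole series and do not explain why the number goes up.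

The compounds shown leave open whether another group on that nitrogen, such as methyl or cyclohexyl, would give a step of similar size. They also leave open whether the isopropyl step would hold on a compound with a longer chain between the two ether oxygens.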